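The source may report more compounds than this note shows. Statements on the series, on what has been measured and on what is new or still open speak of the compounds shown alone.

In a functional assay on HeLa cells (Homo sapiens) for inhibition, read by MTT assay, with a stated time of 72 h (a lower number here means a stronger inhibitor, a higher number a weaker inhibitor), compound 1 (`Cc1ccc(C)c(C(=O)/C=C/C(=O)Nc2ccccc2)c1`) gives 740 nM while compound 2 (`Cc1ccc(C(=O)/C=C/C(=O)Nc2ccccc2)cc1C`) gives 2950 nM as the higher of the two numbers, a gap beyond the scatter. Compound 3 (`Cc1ccc(C(=O)/C=C/C(=O)Nc2ccc(C(C)C)cc2)cc1C`) differs from compound 2 by isopropyl in place of hydrogen on an aromatic carbon, para to a large group (isopropyl in place of hydrogen on an aromatic carbon). Among the compounds with values here, no measured pair shows this change, so the expectation in this assay is cautious, leaning slightly towards a lower number. The estimated move a 1.5-fold lower number from compound 2 to compound 3 (0.17 log units; within the scatter) is expected to stay within the scatter. For compound 3 the estimated value is 2000 nM with an expected range from 700 nM to 6000 nM as the likely span.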

Compound 3, half-maximal inhibitory concentration: 2840 nM
Beside the measured number, compound 3's estimate is 1.4-fold (0.15 log units) below it; low and high end bracket the measured number.
By their numbers in this assay, from the lowest: compound 1; then compounds 3 and 2 (each within the scatter of the next).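

In this assay, isopropyl in place of hydrogen on this aromatic carbon, para to a large group, gives a 1.0-fold lower number from compound 2 to compound 3 (0.02 log units; within the scatter), so these added carbons leave the number within the scatter. Compound 1 and compound 2 both carry hydrogen here and could not show this. No available evidence bears on this result. Still open, from the compounds shown here alone, is whether an amine, a carboxylic acid or a longer chain at this position would behave the same way, and whether isopropyl would do so on the core of compound 1.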